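This account rests on a few compounds, and the source may have more. Where it says the series, first, only, none or still open, it means among the compounds named here.

In a toxicity assay on MCF-10A cells (Homo sapiens) for inhibition, read by MTT assay, with a stated time of 72 h (on this read-out lower numbers stand for stronger inhibition of growth and higher numbers for weaker inhibition of growth), the three measured compounds give the following numbers:

compound 1, `COc1cccc(CNCCCNS(=O)(=O)c2cc(C(F)(F)F)cc(C(F)(F)F)c2)c1`, gives 6600 nM;
compound 2, `O=S(=O)(NCCCNCc1ccccc1Cl)c1cc(C(F)(F)F)cc(C(F)(F)F)c1`, gives 11000 nM;
compound 3, `O=S(=O)(NCCCNCc1ccc(Cl)c(C(F)(F)F)c1)c1cc(C(F)(F)F)cc(C(F)(F)F)c1`, gives 7900 nM.

All three share the same core and differ only in the aryl group on a saturated chain carbon bound to an amine nitrogen. Compound 3 sits among the other two numbers: its nearest neighbour is compound 1, with a 1.2-fold higher number from compound 1 to compound 3 (0.08 log units; within the scatter), and its other neighbour is compound 2, with a 1.4-fold lower number from compound 2 to compound 3 (0.14 log units; within the scatter). Neither gap is beyond the scatter, so the three aryl groups cannot be told apart by these results.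

Compound 4, `COc1ccccc1CNCCCNS(=O)(=O)c1cc(C(F)(F)F)cc(C(F)(F)F)c1`, has not yet been measured. The change from compound 3 is 2-methoxyphenyl in place of 4-chloro-3-(trifluoromethyl)phenyl on a saturated chain carbon bound to an amine nitrogen. For the measured compounds named here, the steps that bear on it are those that swap the same 4-chloro-3-(trifluoromethyl)phenyl for another aryl group: a 1.2-fold higher number from compound 1 to compound 3 (0.08 log units; within the scatter) and a 1.4-fold lower number from compound 2 to compound 3 (0.14 log units; within the scatter), both within the scatter. Nothing in these results therefore points to a step beyond the scatter in this assay in either direction for compound 4, and the step of a 1.1-fold higher number from compound 3 to compound 4 (0.03 log units; within the scatter) is the expectation. Compound 4 is estimated at 8500 nM, with a range from 4000 nM to 18000 nM.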

Compound 4, concentration for 50% growth inhibition: 5500 nM
The estimate for compound 4 lay 1.5-fold (0.19 log units) above the measured number; measured number inside the range.
By their numbers in this assay, from the lowest: compounds 4, 1, 3 and 2 (each within the scatter of the next).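

In this assay, the 2-methoxyphenyl group brings no separation from the aryl groups already seen at this position on a saturated chain carbon bound to an amine nitrogen: the swap for 4-chloro-3-(trifluoromethyl)phenyl gives a 1.4-fold lower number from compound 3 to compound 4 (0.16 log units; within the scatter). This swap replaces a group of 11 heavy atoms with no hydrogen-bond acceptor by one of 8 heavy atoms with 1 hydrogen-bond acceptor, yet the result cannot be told apart from the scatter. The new compound also allows two narrower comparisons, since the swap of 3-methoxyphenyl for 2-methoxyphenyl gives a 1.2-fold lower number from compound 1 to compound 4 (0.08 log units; within the scatter) and methoxy in place of chloro on an aromatic carbon gives a 2.0-fold lower number from compound 2 to compound 4 (0.30 log units; within the scatter), so neither the two methoxyphenyl groups nor the methoxy and chloro groups can be separated by these results.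

Nothing available here offers an explanation for these numbers. Still open, as far as these compounds go, is whether a different kind of group at this position, such as an unsubstituted phenyl, a carboxylic acid or an amide, or a longer chain in the shared core, would produce a step beyond the scatter.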